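The source may hold more compounds than are shown below. What is called first, only, known or untested is meant among the compounds shown, and "the series" means these compounds.

Series notes, cytotoxicity.

The parent of the first pair is compound 1 `O=c1nc2ccccn2cc1Cc1ccc(F)cc1C(F)(F)F`, which in a functional assay on MCF7 cells (Homo sapiens) for cytotoxicity, read by MTT assay, with a stated time of 24 h (a higher number here means a weaker inhibitor, a lower number a stronger inhibitor), gives 9870 nM. Its chloro analogue is compound 3 `O=c1nc2ccc(Cl)cn2cc1Cc1ccc(F)cc1C(F)(F)F`; in this assay compound 3 gives 181000 nM. The structural change between them is chloro in place of hydrogen on an aromatic carbon, and its effect on potency is an 18-fold higher number from compound 1 to compound 3 (1.26 log units; beyond the scatter).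

The second pair is built on a different core. Compound 2 `CC1(C)OC2O[C@@H](Cc3cn4ccccc4nc3=O)C(OCc3ccccc3)C2O1` carries the same heterocycle on a sugar-derived scaffold; how this core differs from the core of compound 1 is not broken down here. In this assay compound 2 gives only a limit, > 1000000 nM, and not a number; this is the limit (the limit of > 1000000 nM in this assay, at which 1 of the 3 values shown sits). Compound 4 `CC1(C)OC2O[C@@H](Cc3cn4cc(Cl)ccc4nc3=O)C(OCc3ccccc3)C2O1` has not yet been measured in this assay. Among the compounds with values here, it differs from compound 2 by chloro in place of hydrogen on an aromatic carbon, which is the same change as the one made from compound 1 to compound 3.

Expectation for compound 4: the one measured instance of this change made the number much higher, as shown by an 18-fold higher number from compound 1 to compound 3 (1.26 log units; beyond the scatter), and the starting point is already at the limit. The step from compound 2 to compound 4 in this assay is therefore estimated at a step that the limit leaves unreadable from compound 2 to compound 4, taken to be of a size similar to the measured one, though with the starting value being a limit the true size is unknowable. Compound 4 is expected to give 10000000 nM, with a range of 1000000 nM to 100000000 nM, and most likely to be reported as a limit again rather than a number.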

Compound 4, half-maximal inhibitory concentration: > 1000000 nM
Compound 4 gave a limit, no number (the forecaster's own chance of this, stated with the estimate: 90%); the middle value is on the limit's open side.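

In this assay, compound 2 and compound 4 both sit at a limit and not at a number, so no step can be read for chloro in place of hydrogen between them: the limit of > 1000000 nM in this assay, at which 2 of the 4 values shown sit.

The compounds shown leave open how large the effect of this change is on the core of compound 2, and whether it resembles an 18-fold higher number from compound 1 to compound 3 (1.26 log units; beyond the scatter).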